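Ester Analogues on a Shared Core: Chloro to Trifluoromethyl

The source may report more compounds than this note shows. Statements on the series, on what has been measured and on what is new or still open speak of the compounds shown alone.

Compound 1 `COc1cccc(C(=O)Oc2cc3c(cc2C)[C@@H](C(C)C)CC=C3C)c1` and compound 2 `CC1=CC[C@H](C(C)C)c2cc(C)c(OC(=O)c3cccc(Cl)c3)cc21` share one core and differ in the substituent on the six-membered aromatic ring of carbon only. In a functional assay on HCT-15 cells (Homo sapiens) for antiproliferative activity, read by sulforhodamine B assay, with a stated time of 48 h, tested at 50 uM (on this read-out higher numbers stand for more inhibition at the one concentration tested (going by the name of the read-out) and lower numbers for less inhibition), compound 1 gives "not active" (no number reported). In this assay compound 2 gives 5.3%, the only number shown, so compound 2 stands alone with nothing to rank against. Compound 3 `CC1=CC[C@H](C(C)C)c2cc(C)c(OC(=O)c3cccc(C(F)(F)F)c3)cc21` has not been measured and carries trifluoromethyl in place of chloro on an aromatic carbon. For the measured compounds named here, no step between measured compounds exists to size this change in this assay. The expected step is none beyond the scatter, a number 2.7 percentage points higher from compound 2 to compound 3 (within the scatter). Compound 3 is estimated at 8% in this assay, with a range from 0% to 20%.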

Compound 3, a percentage reported as inhibition, at one concentration (the size of the read-out at that concentration, not a potency): 15%
Compound 3: the middle estimate sits 7 percentage points below what was measured; measured number inside the range.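

In this assay, for the compounds shown here, trifluoromethyl in place of chloro on an aromatic carbon, meta to a large group, gives a number 9.7 percentage points higher from compound 2 to compound 3 (within the scatter), the first step that can be read at this position. Exchanging the single chlorine for the four heavy atoms of trifluoromethyl therefore does not separate compound 2 from compound 3 on this read-out. No measurement shown gives a reason for this result.

From the compounds shown here alone, whether an amine or a carboxylic acid at this position would separate from chloro and trifluoromethyl stays open. So does the reading of a longer chain there.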